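Shifting a methyl around a pyridine on a shared core

A few compounds are considered here, and "the series" means these few. Any claim that something is new, unique, unknown or untested is made for them only; others in the source may bear on it.

Three compounds share one core and differ only in where a methyl sits on a pyridin-2-yl group. Compound 1 `Cc1cccnc1-c1cc2n(n1)CCN(C(=O)c1ccccc1)C2` carries a 3-methylpyridin-2-yl group; in a functional assay on HEK293 cells for negative allosteric modulation of metabotropic glutamate receptor 5 (Homo sapiens), read by calcium flux, with a stated time of 20 min (a lower number here means a stronger inhibitor, a higher number a weaker inhibitor), compound 1 reaches only the limit of the assay, > 10000 nM, with no number beyond it (the limit of > 10000 nM in this assay, at which 1 of the 3 values shown sits). Compound 2 `Cc1ccnc(-c2cc3n(n2)CCN(C(=O)c2ccccc2)C3)c1` carries a 4-methylpyridin-2-yl group and gives 451 nM. Compound 3 `Cc1ccc(-c2cc3n(n2)CCN(C(=O)c2ccccc2)C3)nc1` carries a 5-methylpyridin-2-yl group and gives 244 nM, the lowest of the two numbers, with compound 2 nearest; the pair is within the scatter, as a 1.8-fold lower number from compound 2 to compound 3 (0.27 log units; within the scatter) shows. The moves from the 3-methyl compound were large: an at least 22-fold lower number from compound 1 to compound 2 (1.34 log units; beyond the scatter) and an at least 40-fold lower number from compound 1 to compound 3 (1.61 log units; beyond the scatter).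

Compound 4 `Cc1cccc(-c2cc3n(n2)CCN(C(=O)c2ccccc2)C3)n1` is the remaining isomer: 6-methylpyridin-2-yl in place of 5-methylpyridin-2-yl on an aromatic carbon. The measured steps show that moving the methyl away from the 3-position matters greatly, while the 4- and 5-positions hardly differ. Among the compounds with values here, no measured step covers a methyl next to the ring nitrogen, so the expectation rests loosely on compound 3 and compound 2. A modest weakening is expected, a 3.3-fold higher number from compound 3 to compound 4 (0.52 log units; beyond the scatter), with wide uncertainty. Compound 4 is estimated at 800 nM, in the range 200 nM to 5000 nM.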

Compound 4, half-maximal inhibitory concentration: 568 nM
For compound 4 the middle estimate is 1.4-fold (0.15 log units) above the measured one; the measured number falls inside the stated range.
By their numbers in this assay, from the lowest: compounds 3, 2 and 4 (each within the scatter of the next, the first and the last beyond it). At a limit, above all of these: compound 1.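

The 6-methylpyridin-2-yl group fills the last methyl position on this pyridine, and in this assay it also gives a large gain over the 3-methylpyridin-2-yl group, with an at least 17-fold lower number from compound 1 to compound 4 (1.24 log units; beyond the scatter). Against the 4-methylpyridin-2-yl group the change makes no real difference, with a 1.3-fold higher number from compound 2 to compound 4 (0.10 log units; within the scatter), while against the 5-methylpyridin-2-yl group it gives a 2.3-fold higher number from compound 3 to compound 4 (0.37 log units; beyond the scatter), a modest step, so among the three compounds with a number only compound 3 and compound 4 can be told apart. The true size of the gain over the 3-methylpyridin-2-yl group stays unknown, since compound 1 stands at a limit and not at a number: the limit of > 10000 nM in this assay, at which 1 of the 4 values shown sits.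

On these data alone, whether the pyridine needs a methyl at all remains open, as does the effect of another group at these positions, such as a chlorine, a methoxy or a trifluoromethyl. The benzoyl group on the shared core is also the same in all four compounds, so nothing here tells how an acetyl group or a longer chain in its place would behave.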